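A few compounds are considered here, and "the series" means these few. Any claim that something is new, unique, unknown or untested is made for them only; others in the source may bear on it.

In a functional assay on the whole organism for inhibition, with Rattus norvegicus as the target, with stated times of 1 h and 3.5 h, at a dose of 100 mg/kg by the oral route (a lower number here means less inhibition, a higher number more inhibition at the dose given (going by the name of the read-out)), compound 3 `CC(C)(C)c1nc(NC#N)ncc1-c1ccccc1` gives < 5%, which is a limit of the assay rather than a number. Compound 1 `N#CNc1nccc(-c2ccncc2)n1` gives < 5% in this assay, again a limit. Compound 2 `CC(C)(C)c1nc(-c2ccccc2)ncc1-c1ccccc1` gives < 5% in this assay, also a limit. The step that the two limits leave unreadable from compound 2 to compound 3 cannot be read, because both of its compounds sit at the limit of < 5% in this assay, at which 3 of the 3 values shown sit. Compound 4 `CC(C)(C)c1nc(NC(=O)CCCC(=O)O)ncc1-c1ccccc1` differs from compound 3 by (3-carboxypropyl)carbonyl in place of cyano on a nitrogen on an aromatic ring. No measured step bears on this change, and the one step shown is unreadable. The step of a number no lower from compound 3 to compound 4 (the limit leaves the size open) is expected to stay within the scatter. The estimate for compound 4 in this assay is 5%, from 0% to 20%, with a further limit the likeliest outcome.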

Compound 4, a percentage reported as inhibition, in the whole organism at one dose (the size of the read-out at that dose, not a potency): 5%
Estimate against measurement, compound 4: no gap at the digits printed; low and high end bracket the measured number.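

In this assay, going by these compounds alone, compound 4 gives 5%, the first value that is a number rather than a limit. Compound 3 gives < 5%, which is a limit. With (3-carboxypropyl)carbonyl in place of cyano on this nitrogen, the result is a number no lower from compound 3 to compound 4 (the limit leaves the size open), and most of the series remains at the limit: the limit of < 5% in this assay, at which 3 of the 4 values shown sit.

The compounds shown leave open whether an amine on this nitrogen would give a clearly higher number. They also leave open whether a longer chain ending in a carboxylic acid would do so.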